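A Second Nitrogen Enters the Sulfonamide

The compounds below may be only part of what the source reports. "The series", "measured", "known", "first", "only" and "open" are said of these compounds alone.

Compound 3 `CCN(CC)S(=O)(=O)c1ccc(C)c(C#Cc2cc(Cl)ccc2OCC(=O)O)c1` gives 3.4 nM in an assay on CHO cells for displacement of a labelled ligand from prostaglandin D2 receptor 2 (Homo sapiens), read by scintillation counting (a lower number here means a stronger inhibitor, a higher number a weaker inhibitor), the lowest of the three numbers measured, although compound 1 `Cc1ccc(S(=O)(=O)N(C)CC(C)C)cc1C#Cc1cc(Cl)ccc1OCC(=O)O` with 4.2 nM lies within the scatter of it: a 1.2-fold lower number from compound 1 to compound 3 (0.09 log units; within the scatter). Compound 2 `Cc1ccc(S(=O)(=O)N(C)CCN(C)C)cc1C#Cc1cc(Cl)ccc1OCC(=O)O`, at 369 nM, is far weaker, as the step of a 110-fold lower number from compound 2 to compound 3 (2.04 log units; beyond the scatter) shows. Compound 4 `Cc1ccc(S(=O)(=O)N2CCN(C)CC2)cc1C#Cc1cc(Cl)ccc1OCC(=O)O` differs from compound 3 by 4-methylpiperazin-1-yl in place of diethylamino on a sulfonyl sulfur, the entering ring carrying a second nitrogen. Going by the values given here, the one measured step that bears on this is the step in which a second nitrogen entered the sulfonamide side chain, an 88-fold higher number from compound 1 to compound 2 (1.94 log units; beyond the scatter). A step in the same direction, perhaps somewhat smaller, is therefore expected: a 44-fold higher number from compound 3 to compound 4 (1.64 log units; beyond the scatter). Compound 4 is estimated at 150 nM, within a range from 30 nM to 800 nM.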

Compound 4, inhibition constant: 21 nM
For compound 4 the middle estimate is 7.1-fold (0.85 log units) above the measured one; the whole stated range lies above it.
By their numbers in this assay, from the lowest: compounds 3 and 1 (each within the scatter of the next); then compound 4; then compound 2.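

A second nitrogen on the sulfonyl sulfur need not cost much: with 4-methylpiperazin-1-yl the change is only a 6.2-fold higher number from compound 3 to compound 4 (0.79 log units; beyond the scatter), and against the other weak-shift neighbour it is a 5.0-fold higher number from compound 1 to compound 4 (0.70 log units; beyond the scatter). The open (2-(dimethylamino)ethyl)(methyl)amino group also carries a second nitrogen, yet the ring gives an 18-fold lower number from compound 2 to compound 4 (1.24 log units; beyond the scatter), so the size of the loss depends on how that nitrogen is carried, not only on its presence. No measurement of any property of these groups is at hand to explain this. Still open, going by these compounds, is how a piperidine ring, with no second nitrogen, or a morpholine ring, with oxygen in its place, would compare.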